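The source may hold more compounds than are shown below. What is called first, only, known or untested is meant among the compounds shown, and "the series" means these compounds.

Among the compounds with values here, compound 3 `C/C=C/C=C/C(=O)N(Cc1ccc(OC)c(O)c1)c1cc(OC)c(OC)c(OC)c1` gives 180 nM in a functional assay on HCT-116 cells (Homo sapiens) for inhibition, read by MTT assay, with a stated time of 48 h (on this read-out higher numbers stand for weaker inhibition and lower numbers for stronger inhibition), the lowest of the three numbers so far, though its neighbours sit close: compound 2 `C=C(C)C(=O)N(Cc1ccc(OC)c(O)c1)c1cc(OC)c(OC)c(OC)c1` gives 200 nM and compound 1 `COc1ccc(CN(C(=O)C=C(C)C)c2cc(OC)c(OC)c(OC)c2)cc1O` gives 290 nM, and the steps of a 1.1-fold lower number from compound 2 to compound 3 (0.05 log units; within the scatter), a 1.6-fold lower number from compound 1 to compound 3 (0.21 log units; within the scatter) and a 1.5-fold lower number from compound 1 to compound 2 (0.16 log units; within the scatter) all lie within the scatter. Compound 4 `COc1ccc(CN(C(=O)CO)c2cc(OC)c(OC)c(OC)c2)cc1O` is made from compound 3 by the change (hydroxymethyl in place of penta-1,3-dien-1-yl on a carbonyl carbon). Every measured step only exchanges one unsaturated chain for another, so none bears directly on this replacement, and the size of the step is open. A weaker result is expected for compound 4, with an 8.3-fold higher number from compound 3 to compound 4 (0.92 log units; beyond the scatter) and an estimated value of 1500 nM, in a range from 300 nM to 8000 nM.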

Compound 4, half-maximal inhibitory concentration: 520 nM
For compound 4 the middle estimate is 2.9-fold (0.46 log units) above the measured one; low and high end bracket the measured number.
By their numbers in this assay, from the lowest: compounds 3, 2, 1 and 4 (each within the scatter of the next, the first and the last beyond it).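

A chain with double bonds is not essential on this carbonyl carbon: hydroxymethyl, with one hydrogen-bond donor and one acceptor, still gives a number of the same general order in this assay. The cost is modest, with a 2.9-fold higher number from compound 3 to compound 4 (0.46 log units; beyond the scatter) and a 2.6-fold higher number from compound 2 to compound 4 (0.41 log units; beyond the scatter), while a 1.8-fold higher number from compound 1 to compound 4 (0.25 log units; within the scatter) shows that the comparison with one of the unsaturated chains stays within the scatter. No measurement here explains the shift. Still open, going by these compounds, is how a longer chain, an amine or a carboxylic acid on this carbonyl carbon would compare. A plain ethyl group would help separate the effect of chain length from that of the hydroxyl oxygen.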